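Phenyl for Phenoxy at One Aromatic Carbon

The source may report more compounds than this note shows. Statements on the series, on what has been measured and on what is new or still open speak of the compounds shown alone.

Compound 1 `Cn1nc(CN2CCCC2)nc1-c1cccc(Oc2ccccc2)c1` carries a phenoxy group on a six-membered aromatic ring of carbon only, attached to a shared core. In an assay on membranes from Jurkat cells for displacement of a labelled ligand from Sigma intracellular receptor 2 (Homo sapiens), read by scintillation counting, with a stated time of 1 h (a higher number here means a weaker inhibitor, a lower number a stronger inhibitor), compound 1 gives > 1000 nM, which is a limit of the assay rather than a number. Two related compounds were measured alongside it. Compound 2 `CC(C)(C)c1ccc(-c2nc(CN3CCCC3)nn2C2CC2)cc1` gives 750 nM in this assay. Compound 3 `Cn1nc(CN2CCCC2)nc1-c1ccc(C(C)(C)C)cc1` gives > 1000 nM in this assay, again a limit rather than a number. Among the compounds with values here, the one step measured between them, an at least 1.3-fold higher number from compound 2 to compound 3 (0.12 log units; that floor lies within the scatter), concerns a group on an aromatic nitrogen and not the phenoxy group, so it does not bear on the change followed here. That change leads to compound 4 `Cn1nc(CN2CCCC2)nc1-c1cccc(-c2ccccc2)c1`: phenyl in place of phenoxy on an aromatic carbon. Within the data shown here, since two of the three values sit at the limit of > 1000 nM in this assay, at which 2 of the 3 values shown sit, the starting point for compound 4 is itself only a floor, and no measured step shows what exchanging one small aromatic group for another does. The expectation is therefore a number close to that floor, with wide uncertainty. Compound 4 is estimated at 1500 nM, within a range from 400 nM to 6000 nM. That estimate means a step that the limit leaves unreadable from compound 1 to compound 4 is expected, that is, no clear change beyond the scatter.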

Compound 4, inhibition constant: 1000 nM
Compound 4: middle estimate off by 1.5-fold (0.18 log units), on the high side; the range from low to high includes it.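

Phenyl in place of phenoxy on this aromatic carbon gives a number no higher from compound 1 to compound 4 (the limit leaves the size open) in this assay. For compound 1, the reading of > 1000 nM is a limit of the assay and not a number. The new information is that compound 4 gives an actual number where compound 1 gives only a limit, yet that number stands right at the limit, so neither phenoxy nor phenyl at this position gives a low number, and the comparison can go no further: the limit of > 1000 nM in this assay, at which 2 of the 4 values shown sit.

Still open, as far as these compounds go, is how far the true value of compound 1 lies from its limit, and therefore whether this exchange changes binding at all or leaves it much the same. Also open, from the compounds shown here alone, is whether a different kind of group on this aromatic carbon, such as an amine, a carboxylic acid or a longer chain, would bring the number clearly down, which would give this position a step of readable size.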